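Compound 3: vinyl in place of the aryl ethenyl group

This account rests on a few compounds, and the source may have more. Where it says the series, first, only, none or still open, it means among the compounds named here.

Values in a functional assay on HL-60 cells (Homo sapiens) for cytotoxicity, read by WST assay, with a stated time of 48 h (a higher number here means a weaker inhibitor, a lower number a stronger inhibitor), so far
compound 1 `O[C@@H](c1ccccc1)[C@H]1CO[C@H](c2ccccc2)[C@@H](C/C=C/c2ccccc2)C1` gives 7040 nM
compound 2 `Oc1ccccc1/C=C/C[C@H]1C[C@@H]([C@@H](O)c2ccccc2)CO[C@@H]1c1ccccc1` gives 10800 nM

Among the measured compounds shown here, compound 2 stands level with compound 1, the only other measured compound, and the gap between them lies within the scatter. The next compound to be measured is compound 3 `C=CC[C@H]1C[C@@H]([C@@H](O)c2ccccc2)CO[C@@H]1c1ccccc1`. The change is vinyl in place of 2-(2-hydroxyphenyl)ethenyl on a saturated chain carbon bound to a saturated ring carbon on a saturated chain carbon bound to a saturated ring carbon, so the whole 2-(2-hydroxyphenyl)ethenyl group gives way to vinyl.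

For the measured compounds named here, only one measured step bears on this (a 1.5-fold higher number from compound 1 to compound 2 (0.19 log units; within the scatter)). It adds hydroxy in place of hydrogen on an aromatic carbon of the group now leaving, and it stays within the scatter. Both measured compounds keep that aromatic ring, so no measurement shows what losing it does. Any forecast is therefore a judgement with wide margins, based on the size of the change alone. A moderate move to a higher number is expected in this assay (estimated: a 2.3-fold higher number from compound 2 to compound 3 (0.36 log units; beyond the scatter)). The expected value for compound 3 is 25000 nM (estimated range 9000 nM to 70000 nM).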

Compound 3, half-maximal inhibitory concentration: 36000 nM
Compound 3: middle estimate off by 1.4-fold (0.16 log units), on the low side; measured number inside the range.
By their numbers in this assay, from the lowest: compounds 1 and 2 (each within the scatter of the next); then compound 3.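

In this assay, the aromatic ring on this group now has a measured bearing: with vinyl in place of 2-(2-hydroxyphenyl)ethenyl on a saturated chain carbon bound to a saturated ring carbon, the result is a 3.3-fold higher number from compound 2 to compound 3 (0.52 log units; beyond the scatter) and, with vinyl in place of 2-phenylethenyl at the same place, a 5.1-fold higher number from compound 1 to compound 3 (0.71 log units; beyond the scatter) as well. The hydroxy on that aromatic ring made no difference beyond the scatter, whereas both steps that remove the ring go beyond it, so among these three compounds the loss of the whole aryl part registers and the hydroxy on it does not. No measurement at hand accounts for this shift.

As far as these compounds go, what remains open is whether the aromatic ring alone carries the difference or whether the length of the chain also plays a part, which a 2-phenylethyl group or a longer chain ending in vinyl would test in this assay directly. Also open, from the compounds shown here alone, is how a methoxy group or an amine on that aromatic ring would compare with the hydroxy.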